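Swapping the aryl group on the thioether linker of compound 3

The source may report more compounds than this note shows. Statements on the series, on what has been measured and on what is new or still open speak of the compounds shown alone.

Of the compounds shown here, three of a shared core have been tested in an assay on isolated protein for binding affinity to Equilibrative nucleoside transporter 1 (Homo sapiens); a higher number here means a weaker inhibitor, a lower number a stronger inhibitor. Compound 1 `CCCCCNc1ncnc2c1ncn2[C@@H]1O[C@H](CO)[C@@H](O)[C@H]1O` gives 13500 nM, compound 2 `OC[C@H]1O[C@@H](n2cnc3c(Sc4ccccc4)ncnc32)[C@H](O)[C@@H]1O` gives 91200 nM, and compound 3 `OC[C@H]1O[C@@H](n2cnc3c(CSc4cccc(Cl)c4)ncnc32)[C@H](O)[C@@H]1O` gives 282 nM. Compound 3 therefore stands lowest of the three, with a 48-fold lower number from compound 1 to compound 3 (1.68 log units; beyond the scatter) and a 320-fold lower number from compound 2 to compound 3 (2.51 log units; beyond the scatter), both well beyond the scatter, while a 6.8-fold higher number from compound 1 to compound 2 (0.83 log units; beyond the scatter) is modest.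

Compound 4 `CC(C)(C)c1ccc(SCc2ncnc3c2ncn3[C@@H]2O[C@H](CO)[C@@H](O)[C@H]2O)cc1` has not yet been measured. It differs from compound 3 in one place: 4-(tert-butyl)phenyl in place of 3-chlorophenyl on a sulfur. Within the data shown here, none of the measured steps changes only the ring that hangs on the sulfur; the two large steps ending at compound 3 replace the whole side group at once, so they show that this part of the molecule weighs heavily on the result without saying which ring suits it best. The swap in compound 4 keeps the sulfur and the chain carbon and only alters the ring, so a step smaller than those two is expected, in either direction, but it may well exceed the scatter. Compound 4 is estimated at 500 nM, within 100 nM to 3000 nM, meaning an expected step of a 1.8-fold higher number from compound 3 to compound 4 (0.25 log units; within the scatter).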

Compound 4, half-maximal inhibitory concentration: 331000 nM
Compound 4: middle estimate off by 660-fold (2.82 log units), on the low side, outside the stated range (above it).
By their numbers in this assay, from the lowest: compound 3; then compound 1; then compound 2; then compound 4.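

In this assay the ring on the sulfur matters in its own right: with the sulfur and the saturated chain carbon kept, 4-(tert-butyl)phenyl in place of 3-chlorophenyl gives a 1200-fold higher number from compound 3 to compound 4 (3.07 log units; beyond the scatter) in the only step shown that changes this ring alone. That step is larger than the two that replace the whole side group, a 48-fold lower number from compound 1 to compound 3 (1.68 log units; beyond the scatter) and a 320-fold lower number from compound 2 to compound 3 (2.51 log units; beyond the scatter) on the way to the same compound, so the side group's good result in compound 3 does not carry over to any ring placed on the sulfur. No measurement here explains why this swap has so large an effect on the number.

The swap removes the chlorine and brings in the tert-butyl group in a different ring position at once, so the compounds shown cannot assign the change to either the group or its position. A 4-chlorophenyl or 3-(tert-butyl)phenyl ring on the same sulfur would separate the two, and a ring carrying a methoxy group or an amine would show how far this position tolerates other groups.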